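This account rests on a few compounds, and the source may have more. Where it says the series, first, only, none or still open, it means among the compounds named here.

Compound 1, whose structure is `C=CCOc1ccc(F)cc1C(=O)c1cccnc1`, was tested in a functional assay on HeLa cells (Homo sapiens) for cytotoxicity, read by sulforhodamine B assay, with a stated time of 48 h (on this read-out lower numbers stand for stronger inhibition and higher numbers for weaker inhibition), and gives 93000 nM. Among the two numbers measured in this assay, compound 1 stands as the highest; its nearest neighbour is compound 3, with the structure `O=C(c1cccnc1)c1ccccc1O`, which in this assay gives 33000 nM, a lower number by a gap that lies beyond the usual scatter. Compound 2, with the structure `C=CCOc1cc(Br)ccc1C(=O)c1cccnc1`, gives in this assay only a limit, > 100000 nM, and no number; this reflects (the limit of > 100000 nM in this assay, at which 1 of the 3 values shown sits). The unmeasured compound 4, with the structure `C=CCOc1ccc(Br)cc1C(=O)c1cccnc1`, differs from compound 1 in one place: bromo in place of fluoro on an aromatic carbon. Among the measured compounds shown here, no pair of measured compounds shows this change by itself, so its size can only be expected, not read off. With the number of compound 1 already standing at 93000 nM, the change is expected to leave the number at about the same level or move it somewhat higher, not beyond the scatter in either direction with confidence. Compound 4 is therefore estimated at 95000 nM, within a range from 40000 nM to 220000 nM, which means an expected step of a 1.0-fold higher number from compound 1 to compound 4 (0.01 log units; within the scatter).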

Compound 4, half-maximal inhibitory concentration: 96000 nM
Beside the measured number, compound 4's estimate is 1.0-fold (0.00 log units) below it, within the range that was stated.
By their numbers in this assay, from the lowest: compound 3; then compounds 1 and 4 (each within the scatter of the next). At a limit, above all of these: compound 2.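

In this assay, bromo in place of fluoro on this aromatic carbon, para to an allyloxy group, gives a 1.0-fold higher number from compound 1 to compound 4 (0.01 log units; within the scatter). Among the compounds shown here, this is the first pair that shows the change by itself, and it does not separate the two halogens at this place, so compound 1 and compound 4 cannot be told apart in this read-out. No information given here accounts for this result.

What the compounds shown leave open is whether a group of another kind at this place, such as an amine, a methoxy group or a carboxylic acid, would give a number that stands apart from those of compound 1 and compound 4. They also leave open whether bromo and fluoro would stay level at any other position of the ring.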